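The compounds below may be only part of what the source reports. "The series", "measured", "known", "first", "only" and "open" are said of these compounds alone.

Of the compounds shown here, two have so far been measured in an assay on isolated protein for inhibition of Amine oxidase [flavin-containing] B (Homo sapiens), read by fluorescence, with stated times of 15 min and 20 min; on this read-out lower numbers stand for stronger inhibition and higher numbers for weaker inhibition. Compound 1, `CC(C)(C)c1cc(CCC(=O)NC2CCN(Cc3ccccc3)CC2)cc(C(C)(C)C)c1O`, carries a saturated three-carbon linker and an amide bound directly to the piperidine ring; in this assay compound 1 gives 70400 nM. Compound 2, `CC(C)(C)c1cc(/C=C/C(=O)NCCC2CCN(Cc3ccccc3)CC2)cc(C(C)(C)C)c1O`, differs at more than one place, with an unsaturated linker and an ethylene spacer between the amide and the piperidine; in this assay compound 2 gives 8500 nM. Compound 2 thus stands at the lowest of the two numbers, and the gap to compound 1 lies beyond the usual scatter.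

The step now taken leads to compound 3, `CC(C)(C)c1cc(/C=C/C(=O)NCCC2CCN(Cc3ccccc3F)CC2)cc(C(C)(C)C)c1O`. The difference from compound 2 is fluoro in place of hydrogen on an aromatic carbon, that is, a fluoro in place of hydrogen on an aromatic carbon of the benzyl group. For the measured compounds named here, no comparable step between measured compounds is available, so the expectation rests on the single value of compound 2 alone. A change of this kind, one fluorine entering a benzyl ring, is expected to move the number little, if at all, and the step of a 1.2-fold lower number from compound 2 to compound 3 (0.08 log units; within the scatter) is expected to stay within the scatter. Compound 3 is therefore estimated at 7000 nM, with a range from 2500 nM to 20000 nM.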

Compound 3, half-maximal inhibitory concentration: 7400 nM
For compound 3 the middle estimate is 1.1-fold (0.02 log units) below the measured one; the measured number falls inside the stated range.
By their numbers in this assay, from the lowest: compounds 3 and 2 (each within the scatter of the next); then compound 1.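

In this assay, for the compounds shown here, the first comparison at a single place reads a 1.1-fold lower number from compound 2 to compound 3 (0.06 log units; within the scatter), so this is the first direct reading of a change on the benzyl group, since compound 1 and compound 2 differ at more than one place. It shows that, in this pair, fluoro on an aromatic carbon of the six-membered ring, ortho to a large group, leaves the number within the scatter, and benzyl and 2-fluorobenzyl cannot be told apart in this read-out. No measurement available here offers an explanation for this outcome.

The compounds shown leave open whether this tolerance extends to larger or different groups on the same ring, such as chloro, methoxy, trifluoromethyl, an amine or a carboxylic acid, and whether fluoro at another carbon of the ring would read the same. They also leave open how much of the gap between compound 1 and compound 2 belongs to the unsaturated linker and how much to the ethylene spacer, as those two differences cannot be read apart.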